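A few compounds are considered here, and "the series" means these few. Any claim that something is new, unique, unknown or untested is made for them only; others in the source may bear on it.

Compound 3 (`COc1ccc(/C=C/C(=O)Nc2cc3c(Nc4ccc(F)c(Cl)c4)ncnc3cc2O[C@H]2CCOC2)cc1`), which carries 4-methoxyphenyl, gives 3050 nM in a functional assay on A549 cells (Homo sapiens) for cytotoxicity, read by MTT assay, with a stated time of 72 h; on this read-out lower numbers stand for stronger inhibition and higher numbers for weaker inhibition. That is the middle of three numbers from compounds sharing one core: compound 1 (`COc1ccc(/C=C/C(=O)Nc2cc3c(Nc4ccc(F)c(Cl)c4)ncnc3cc2O[C@H]2CCOC2)c(OC)c1OC`) lies lower at 70 nM, and compound 2 (`COc1cc(/C=C/C(=O)Nc2cc3c(Nc4ccc(F)c(Cl)c4)ncnc3cc2O[C@H]2CCOC2)cc(OC)c1`) lies higher at 10800 nM. Compound 4 (`O=C(/C=C/c1ccc(Br)cc1)Nc1cc2c(Nc3ccc(F)c(Cl)c3)ncnc2cc1O[C@H]1CCOC1`) has not yet been measured. It replaces the 4-methoxyphenyl of compound 3 with 4-bromophenyl, bromo in place of methoxy on an aromatic carbon.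

Among the measured compounds shown here, no measured step makes this exchange, and no measured compound carries bromo, so the evidence is indirect. Three steps alter the substituents on the same aromatic ring. Two are large, a 44-fold higher number from compound 1 to compound 3 (1.64 log units; beyond the scatter) and a 150-fold higher number from compound 1 to compound 2 (2.19 log units; beyond the scatter), and both start from compound 1, whose ring differs from the others by more than one group. The third, a 3.5-fold lower number from compound 2 to compound 3 (0.55 log units; beyond the scatter), is modest and is the closer guide for a swap of one group. In this assay, a modest step is therefore expected at most, and the data favour no clear direction. The estimated step is a 1.2-fold lower number from compound 3 to compound 4 (0.09 log units; within the scatter). For compound 4 the estimated value is 2500 nM, with an expected range from 700 nM to 9000 nM.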

Compound 4, half-maximal inhibitory concentration: 35300 nM
Beside the measured number, compound 4's estimate is 14-fold (1.15 log units) below it; measured number above the stated range.
By their numbers in this assay, from the lowest: compound 1; then compound 3; then compound 2; then compound 4.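

In this assay, among the compounds shown here, bromo in place of methoxy on an aromatic carbon, para to a large group, gives a 12-fold higher number from compound 3 to compound 4 (1.06 log units; beyond the scatter); this shows that a change at this one place can by itself produce a large step, whereas the earlier steps on this ring each changed the pattern of methoxy groups. The other two comparisons are a 3.3-fold higher number from compound 2 to compound 4 (0.51 log units; beyond the scatter) and a 500-fold higher number from compound 1 to compound 4 (2.70 log units; beyond the scatter), so 4-bromophenyl gives the highest number of the four, and the ring's substituents span a wider range than compounds 1, 2 and 3 alone had shown. Nothing among the data given accounts for this shift.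

The compounds shown leave open whether the high number goes with bromo specifically or with the loss of methoxy, a question that fluoro, chloro, methyl or an amine on the same carbon would help to settle. They also leave open whether bromo in place of methoxy has a step of similar size on a ring that keeps further methoxy groups, as the ring of compound 1 does.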